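From 2-chlorophenyl to 4-fluorophenyl on the shared core

The source may report more compounds than this note shows. Statements on the series, on what has been measured and on what is new or still open speak of the compounds shown alone.

In an ADME assay on BHK-21 cells (Mesocricetus auratus) for cytotoxicity, read by MTT assay, with a stated time of 72 h (on this read-out higher numbers stand for lower toxicity in this test and lower numbers for higher toxicity in this test), compound 3 (`NS(=O)(=O)c1ccc(N2N=C(c3ccc(Oc4ccccc4)cc3)CC2c2ccccc2Cl)cc1`) gives 8000 nM. Going by the values given here, that is the smallest number so far, but it lies within the scatter of compound 2 (`NS(=O)(=O)c1ccc(N2N=C(c3ccc(Oc4ccccc4)cc3)CC2c2ccccc2)cc1`), which gives 11000 nM. Only compound 1 (`NS(=O)(=O)c1ccc(N2N=C(c3ccc(OCc4ccccc4)cc3)CC2c2ccc(F)cc2)cc1`), at 60000 nM, stands clearly higher.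

The next molecule, compound 4 (`NS(=O)(=O)c1ccc(N2N=C(c3ccc(Oc4ccccc4)cc3)CC2c2ccc(F)cc2)cc1`), places 4-fluorophenyl in place of 2-chlorophenyl on a saturated ring carbon.

One measured change touches this same aromatic ring. Putting chloro in place of hydrogen gave a 1.4-fold lower number from compound 2 to compound 3 (0.14 log units; within the scatter), so that ring has shown little influence on the number so far. Compound 4 differs elsewhere too from compound 1, which also carries 4-fluorophenyl, so the value of compound 1, 60000 nM, only widens the upper end of the expectation.

The expected step is therefore small, with nothing beyond the scatter anticipated: a 1.4-fold higher number from compound 3 to compound 4 (0.14 log units; within the scatter).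

For compound 4 the estimated value is 11000 nM, with an expected range from 5000 nM to 28000 nM.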

Compound 4, half-maximal cytotoxic concentration: 8000 nM
Beside the measured number, compound 4's estimate is 1.4-fold (0.14 log units) above it; measured number inside the range.
By their numbers in this assay, from the lowest: compounds 3, 4 and 2 (each within the scatter of the next); then compound 1.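

In this assay, 4-fluorophenyl in place of 2-chlorophenyl on the saturated ring carbon gives no change at the digits printed from compound 3 to compound 4 (within the scatter), and fluoro in place of hydrogen on the same aromatic ring gives a 1.4-fold lower number from compound 2 to compound 4 (0.14 log units; within the scatter). Phenyl, 2-chlorophenyl and 4-fluorophenyl at this position therefore cannot be told apart in this test. Going by these compounds alone, the only step here beyond the scatter lies elsewhere, on the oxygen: with 4-fluorophenyl now present on both sides of the comparison, phenyl in place of benzyl gives a 7.5-fold lower number from compound 1 to compound 4 (0.88 log units; beyond the scatter).

Only plain and halogen-bearing phenyl rings appear at this position, so an amine or a carboxylic acid on that ring remains an open case. Also open, on these data alone, is whether the step between benzyl and phenyl holds with 2-chlorophenyl or plain phenyl on the saturated ring carbon. No supporting measurement accompanies these results.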